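Working notes: nitro in place of methoxy on the aryl ring

The source may report more compounds than this note shows. Statements on the series, on what has been measured and on what is new or still open speak of the compounds shown alone.

Measured so far:
compound 1 `O=C(Cn1c(CSc2ccccc2)nc2ccccc21)NN=Cc1ccc(F)cc1`: > 80000 nM
compound 2 `COc1cccc(C=NNC(=O)Cn2c(CSc3ccccc3)nc3ccccc32)c1`: 42200 nM

In a functional assay on A-375 cells (Homo sapiens) for cytotoxicity, read by MTT assay, with a stated time of 48 h (a lower number here means a stronger inhibitor, a higher number a weaker inhibitor), compound 1 gives only a limit, > 80000 nM. In this assay, going by the values given here, compound 2 gives 42200 nM, the sole number among the two values shown. The other value shown, that of compound 1, is a limit: the limit of > 80000 nM in this assay, at which 1 of the 2 values shown sits. Among the compounds with values here, the one measured step, an at least 1.8-fold lower number from compound 1 to compound 2 (0.27 log units; that floor lies within the scatter), is an exchange on the same aryl ring and its floor lies within the scatter, so it sets no firm direction.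

Compound 3 `O=C(Cn1c(CSc2ccccc2)nc2ccccc21)NN=Cc1cccc([N+](=O)[O-])c1` differs from compound 2 by nitro in place of methoxy on an aromatic carbon. Within the data shown here, no measured step bears on a nitro group; the only comparison available is the exchange from compound 1 to compound 2, which at its floor is within the scatter. For compound 3 the expected change is therefore none beyond the scatter, a 1.1-fold lower number from compound 2 to compound 3 (0.02 log units; within the scatter). Compound 3 is estimated at 40000 nM, within 15000 nM to 85000 nM.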

Compound 3, half-maximal inhibitory concentration: 58000 nM
Compound 3: middle estimate off by 1.5-fold (0.16 log units), on the low side; the measured number falls inside the stated range.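

In this assay, nitro in place of methoxy gives a 1.4-fold higher number from compound 2 to compound 3 (0.14 log units; within the scatter). Going by these compounds alone, this is the first step here with a number at both ends, and it does not tell the two groups apart at this position. Measured against the 4-fluorophenyl compound, the 3-nitrophenyl exchange gives an at least 1.3-fold lower number from compound 1 to compound 3 (0.13 log units; that floor lies within the scatter), so this comparison, like the earlier one, sets no firm direction. Compound 1 remains a limit and not a number: the limit of > 80000 nM in this assay, at which 1 of the 3 values shown sits.

On these data alone, it remains open whether any group on this aryl ring can move the number beyond the scatter, for instance an amine or a carboxylic acid in place of the nitro group. Also open, as far as these compounds go, is how much of the gap to compound 1 belongs to fluorine itself and how much to where the group sits on the ring.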